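The source may hold more compounds than are shown below. What is called first, only, known or untested is meant among the compounds shown, and "the series" means these compounds.

Three compounds share one sugar-bearing core and differ only in the ring that hangs off it. In a physicochemical assay for solubility, measured as kinetic solubility, with a stated time of 15 h, at pH 7.4 (a lower number here means a less soluble compound, a higher number a more soluble compound), compound 1 `OC[C@H]1O[C@H](Oc2ccc(-c3ccc(Cl)cc3Cl)cc2Cl)[C@@H](O)[C@@H](O)[C@@H]1O` gives 8 ug/mL. In this assay compound 2 `OC[C@H]1O[C@H](Oc2ccc(-c3ccccc3Cl)cc2Cl)[C@@H](O)[C@@H](O)[C@@H]1O` gives 28 ug/mL. In this assay compound 3 `Cc1ccc(-c2ccc(O[C@H]3O[C@H](CO)[C@@H](O)[C@H](O)[C@@H]3O)c(Cl)c2)cc1` gives 7.4 ug/mL. Compound 2 therefore stands highest of the three, since a 3.5-fold higher number from compound 1 to compound 2 (0.54 log units; beyond the scatter) and a 3.8-fold lower number from compound 2 to compound 3 (0.58 log units; beyond the scatter) are both beyond the scatter. Compound 4 `O=[N+]([O-])c1cccc(-c2ccc(O[C@H]3O[C@H](CO)[C@@H](O)[C@H](O)[C@@H]3O)c(Cl)c2)c1` differs from compound 2 by 3-nitrophenyl in place of 2-chlorophenyl on an aromatic carbon. The two steps that touch the same 2-chlorophenyl group or its chloro were both modest, so a modest move is expected for compound 4, more likely downward, giving a 1.6-fold lower number from compound 2 to compound 4 (0.19 log units; within the scatter). Compound 4 is estimated at 18 ug/mL, with a range from 6 ug/mL to 55 ug/mL.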

Compound 4, solubility: 23 ug/mL
Compound 4: the middle estimate sits 1.3-fold (0.11 log units) below what was measured, within the range that was stated.
By their numbers in this assay, from the lowest: compounds 3 and 1 (each within the scatter of the next); then compounds 4 and 2 (each within the scatter of the next).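

In this assay, 3-nitrophenyl at this position stays level with 2-chlorophenyl, with a 1.2-fold lower number from compound 2 to compound 4 (0.09 log units; within the scatter), so the higher level does not depend on a chloro group on this ring. The same change stands clear of the two lower compounds, with a 3.1-fold higher number from compound 3 to compound 4 (0.49 log units; beyond the scatter) and a 2.9-fold higher number from compound 1 to compound 4 (0.46 log units; beyond the scatter). Nothing available here bears on why these numbers fall as they do. From the compounds shown here alone, whether an amine or a carboxylic acid in place of the nitro group would hold this level remains open, as does the effect of replacing the ring with a longer chain.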